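This account rests on a few compounds, and the source may have more. Where it says the series, first, only, none or still open, it means among the compounds named here.

Measured so far in a physicochemical assay for lipophilicity, using the shake flask method, in phosphate buffer, measured as octanol-water partition, at pH 7.4 (on this read-out lower numbers stand for lower lipophilicity and higher numbers for higher lipophilicity), are two compounds:

Compound 1 `CC[C@H](c1ccc(C(=O)O)c(Oc2cccc(Cl)c2)c1OC)N1CCC[C@H](n2cc(C)c(=O)[nH]c2=O)C1` gives -0.13
Compound 2 `CC[C@@H](c1ccc(C(=O)O)c(Oc2cccc(Cl)c2)c1)N1CCC[C@H](n2cc(C)c(=O)[nH]c2=O)C1` gives 0.22

Compound 1 stands lowest of these two, and compound 2 lies higher by a gap beyond the scatter. Compound 3 `COc1c(CN2CCC[C@H](n3cc(C)c(=O)[nH]c3=O)C2)ccc(C(=O)O)c1Oc1cccc(Cl)c1` has no number yet. It differs from compound 1 by hydrogen in place of ethyl on a saturated chain carbon bound to an amine nitrogen in a ring and an aromatic carbon with hydrogen in place of ethyl on a saturated chain carbon bound to an amine nitrogen in a ring and an aromatic carbon. Among the measured compounds shown here, no measured pair shows this change, so the expectation rests on judgement alone. The estimated a number 0.62 log units lower from compound 1 to compound 3 (beyond the scatter) is expected to be a fall beyond the scatter. For compound 3 the expected value is -0.75 in this assay with an estimated range of -1.2 to -0.3 around it.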

Compound 3, distribution coefficient: -0.77
Compound 3: the middle estimate sits 0.02 log units above what was measured, and the stated range covers the measured number.
By their numbers in this assay, from the lowest: compound 3; then compound 1; then compound 2.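

Among the compounds shown here, replacing ethyl with hydrogen on a saturated chain carbon bound to an amine nitrogen in a ring and an aromatic carbon gives the first comparison in this assay that changes one place only, and the number falls (a number 0.64 log units lower from compound 1 to compound 3 (beyond the scatter)). This position therefore matters for the read-out, which compound 1 and compound 2 could not show, as they differ in more than one place. Nothing at hand gives a reason for this fall. As far as these compounds go, whether methyl at this carbon would place the number between those of compound 3 and compound 1 remains open, as does whether a longer chain such as propyl would raise it past that of compound 1.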